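The compounds below may be only part of what the source reports. "The series", "measured", "known", "first", "only" and "open" are said of these compounds alone.

The measured compounds:

Compound 1 `Cc1nc(-c2ccccc2)sc1C(=O)CSc1nc(N)c(C#N)c(-c2ccc(Cl)cc2)n1` gives 58.8% in a functional assay on U-87MG ATCC cells for antiproliferative activity against U-87 MG (Homo sapiens), read by MTT assay, with a stated time of 48 h, tested at 10 uM; a higher number here means a weaker effect of the compound at the concentration tested, a lower number a stronger effect.
Compound 2 `Cc1nc(-c2ccc(Cl)cc2)sc1C(=O)CSc1nc(N)c(C#N)c(-c2ccc(Cl)cc2)n1` gives 37.3% in this assay.
Compound 3 `Cc1nc(-c2ccccc2)sc1C(=O)CSc1nc(-c2ccc(Cl)cc2)c(C#N)c(=O)[nH]1` gives 85.2% in this assay.

Compound 1 and compound 2 share one core and differ in a single place: chloro in place of hydrogen on an aromatic carbon. That change brought the step of a number 21.5 percentage points lower from compound 1 to compound 2 (beyond the scatter), a drop that lies beyond the usual scatter. Compound 3 carries a different core, and the difference between the two cores is not broken down here; its value stands highest of the three. Compound 4 `Cc1nc(-c2ccc(Cl)cc2)sc1C(=O)CSc1nc(-c2ccc(Cl)cc2)c(C#N)c(=O)[nH]1` is not yet measured in this assay and differs from compound 3 by the same kind of change: chloro in place of hydrogen on an aromatic carbon. This change has been seen only once among the compounds shown, on the other core, so how far it carries over is open. Resting on the step of a number 21.5 percentage points lower from compound 1 to compound 2 (beyond the scatter), the writer expects a step of roughly similar size on the second core, namely a number 20.2 percentage points lower from compound 3 to compound 4 (beyond the scatter). The estimate for compound 4 in this assay is therefore 65%, with a range from 45% to 85%.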

Compound 4, a percentage reported as activity, at one concentration (the size of the read-out at that concentration, not a potency): 98.4%
Beside the measured number, compound 4's estimate is 33.4 percentage points below it, and the stated range ends below it.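

In this assay, the change from phenyl to 4-chlorophenyl did not carry over from one core to the other: on the core of compound 3 it gave a number 13.2 percentage points higher from compound 3 to compound 4 (beyond the scatter), a weaker effect, while on the core of compound 1 it had given a stronger one. Among the compounds shown here, the two steps run in opposite directions, and the gap between them is larger than chance scatter would readily explain: the same change on two cores in this assay, a number 21.5 percentage points lower (beyond the scatter) from compound 1 to compound 2 and a number 13.2 percentage points higher (beyond the scatter) from compound 3 to compound 4, 34.7 percentage points apart, beyond the scatter of two such steps This shows that, in these two pairs, the outcome of adding the chloro group depends on the core it is attached to, but with only one pair on each core it does not show which part of the core decides the direction, or why.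

From the compounds shown here alone, whether a fluoro, a methoxy or a trifluoromethyl group in the same place would split between the two cores in the same way remains open. Also open is how the effects of these compounds would compare at other concentrations: the read-out gives the size of the effect at a single concentration.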